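Aryl ketone in place of cyclopropyl ketone on the shared core

The source may hold more compounds than are shown below. What is called first, only, known or untested is meant among the compounds shown, and "the series" means these compounds.

Compound 2 `COc1cc(-c2nnc3n2NC(c2ccco2)C(C(=O)C2CC2)S3)cc(OC)c1OC` sits at a limit: in a functional assay on MCF7 cells (Homo sapiens) for cytotoxicity, read by MTT assay, with a stated time of 48 h (a lower number here means a stronger inhibitor, a higher number a weaker inhibitor), compound 2 gives > 100000 nM, a limit of the assay and not a number. Compound 1 `COc1cc(-c2nnc3n2NC(c2cccs2)C(C(=O)c2ccccc2)S3)cc(OC)c1OC` likewise gives > 100000 nM in this assay, also a limit. Compound 3 `COc1cc(-c2nnc3n2NC(c2cccs2)C(C(=O)c2ccc(Cl)cc2)S3)cc(OC)c1OC` gives 42800 nM in this assay. For the measured compounds named here, the only measured step with a direction is an at least 2.3-fold lower number from compound 1 to compound 3 (0.36 log units; beyond the scatter), and the limit of > 100000 nM in this assay, at which 2 of the 3 values shown sit, marks where two of the three values rest.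

Compound 4 `COc1cc(-c2nnc3n2NC(c2ccco2)C(C(=O)c2ccccc2C)S3)cc(OC)c1OC` differs from compound 2 in one place: 2-methylphenyl in place of cyclopropyl on a carbonyl carbon. Going by the values given here, no measured step covers this exchange; the step from compound 1 to compound 3 concerns chloro on an aromatic carbon and says nothing about cyclopropyl against 2-methylphenyl. Compound 1, whose structure stands beside it, is itself at a limit. Compound 4 is therefore expected to remain near the limit, with no step beyond the scatter: an at least 1.1-fold lower number from compound 2 to compound 4 (0.04 log units; that floor lies within the scatter). The estimate for compound 4 is 90000 nM, within 30000 nM to 300000 nM.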

Compound 4, half-maximal inhibitory concentration: 69900 nM
Compound 4: the middle estimate sits 1.3-fold (0.11 log units) above what was measured; the measured number falls inside the stated range.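

The exchange of cyclopropyl for 2-methylphenyl on a carbonyl carbon gives the first step shown at this position: an at least 1.4-fold lower number from compound 2 to compound 4 (0.15 log units; that floor lies within the scatter), a floor that supports no claim of a real gain. In this assay compound 4 gives 69900 nM with no chloro on its 2-methylphenyl, so a measured number in this series does not require that group. Going by these compounds, the true size of the step stays unknown because compound 2 rests on a limit and not a number: the limit of > 100000 nM in this assay, at which 2 of the 4 values shown sit.

The compounds shown leave open how far the step exceeds its floor and whether the methyl of 2-methylphenyl contributes anything on this core. On these data alone, how a longer alkyl chain or an amine-bearing chain on the carbonyl carbon would read in this assay also remains open.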